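Acetamido in place of methoxymethyl on the distal phenyl

The source may hold more compounds than are shown below. What is called first, only, known or untested is meant among the compounds shown, and "the series" means these compounds.

Measured so far:
compound 1, `CC[C@H](C)[C@H](N)CN(C(=O)[C@@H]1C[C@H]1c1ccccc1)c1ccc(-c2ccccc2)cc1`: 230 nM; 800 nM (2 entries)
compound 2, `CC[C@H](C)[C@H](N)CN(C(=O)[C@@H]1C[C@H]1c1ccccc1)c1ccc(-c2ccc(COC)cc2)cc1`: 35 nM

In a functional assay for agonist activity at G protein-coupled receptor 88 (Homo sapiens), read by HTRF and cAMP accumulation (on this read-out higher numbers stand for an effect only at larger amounts of compound and lower numbers for an effect already at smaller amounts), compound 1 gives 230 nM; 800 nM (2 entries), two entries that themselves spread apart (the several entries of compound 1 in this assay, 230 nM; 800 nM (2 entries)). Compound 2 gives 35 nM, the lowest number shown and the only number for compound 2 in this assay.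

Compound 3, `CC[C@H](C)[C@H](N)CN(C(=O)[C@@H]1C[C@H]1c1ccccc1)c1ccc(-c2ccc(NC(C)=O)cc2)cc1`, has not been measured. It differs from compound 2 only as acetamido in place of methoxymethyl on an aromatic carbon.

Among the compounds with values here, no measured pair shows this change. The expectation for compound 3 is therefore a small shift, estimated as a step of a 2.0-fold higher number from compound 2 to compound 3 (0.30 log units; within the scatter), toward larger amounts but not beyond what repeat measurements scatter. Compound 3 is expected at 70 nM, in the range 20 nM to 300 nM.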

Compound 3, half-maximal effective concentration: 5500 nM
Estimate against measurement, compound 3: 79-fold (1.90 log units) below; the measured number lies above the stated range.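

This position is sharply sensitive to the group it carries: in this assay, acetamido in place of methoxymethyl gives a 160-fold higher number from compound 2 to compound 3 (2.20 log units; beyond the scatter). Substitution here is therefore not favourable as such, since compound 3 at 5500 nM also stands above both entries of the unsubstituted compound 1, whose spread does not close that gap: the several entries of compound 1 in this assay, 230 nM; 800 nM (2 entries)

Going by these compounds, whether the loss follows the amide as a whole or the added hydrogen-bond donor stays open. Hydroxymethyl, a primary amine or a methoxy group on the same carbon would help separate these readings.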